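Macrocyclic aldehydes and their cytotoxicity on liver cells

The source may report more compounds than this note shows. Statements on the series, on what has been measured and on what is new or still open speak of the compounds shown alone.

Measured compounds:
compound 1, `O=C[C@@H]1CCC(=O)NCCn2cc(nn2)C[C@H](NC(=O)OCc2ccccc2)C(=O)N[C@@H](CC2CCCCC2)C(=O)N1` — > 100000 nM
compound 2, `CC(C)C[C@@H]1NC(=O)[C@@H](NC(=O)OCc2ccccc2)Cc2cn(nn2)CCCCCCNC(=O)CC[C@@H](C=O)NC1=O` — > 100000 nM

The two measured compounds share a macrocyclic core closed through a triazole and carry an aldehyde on the ring. They were tested in an ADME assay on HG23 cells (Homo sapiens) for cytotoxicity, with a stated time of 72 h; on this read-out higher numbers stand for lower toxicity in this test and lower numbers for higher toxicity in this test. In this assay compound 1 reached only the limit of the assay, > 100000 nM, and no number was obtained. Compound 2 likewise stopped at the limit, > 100000 nM, which is not a number but the edge of the measured range. Thus compound 2 stands where every value shown stands, namely (the limit of > 100000 nM in this assay, at which 2 of the 2 values shown sit), and no step between measured compounds can be drawn from these two results.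

Compound 3, `O=C[C@@H]1CCC(=O)NCCCCCCn2cc(nn2)C[C@H](NC(=O)OCc2ccccc2)C(=O)N[C@@H](Cc2ccccc2)C(=O)N1`, is the next member. Compared with compound 2 the change is phenyl in place of isopropyl on a saturated chain carbon bound to a saturated ring carbon, or put one bond further out, isobutyl to benzyl; the ring and the remaining side chains stay as they are.

Among the measured compounds shown here, because both known values sit at the limit (the limit of > 100000 nM in this assay, at which 2 of the 2 values shown sit), no measured step is available to size the change in this assay. The expectation for the step that the limit leaves unreadable from compound 2 to compound 3 is therefore none beyond the scatter. Compound 3 is expected to give 120000 nM in this assay, estimated between 40000 nM and 400000 nM, and most likely to be reported again as a limit rather than a number.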

Compound 3, half-maximal cytotoxic concentration: > 100000 nM
Compound 3 gave a limit, no number; the forecaster's own chance of this, stated with the estimate: 80%; the middle value does not contradict the limit.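

In this assay compound 3 gives > 100000 nM, which is a limit and not a number. Among the compounds shown here, no step can therefore be read from compound 2 to compound 3, so the change from isobutyl to benzyl cannot be sized. The compounds shown leave open whether any change among them alters this read-out, as all results coincide: the limit of > 100000 nM in this assay, at which 3 of the 3 values shown sit.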